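The source may hold more compounds than are shown below. What is called first, only, known or untested is meant among the compounds shown, and "the series" means these compounds.

Working notes on the series. The shared core of compound 1 `CN(c1cccc2c1CN(c1nc(Nc3ccc(C(F)(F)F)cc3)ncc1C(F)(F)F)C2)S(C)(=O)=O` is kept in every member; the compounds differ only in the aryl group carried on the nitrogen. In a functional assay on U-87MG ATCC cells for antiproliferative activity against U-87 MG (Homo sapiens), read by spectrophotometry, with a stated time of 2 days (a lower number here means a stronger inhibitor of growth, a higher number a weaker inhibitor of growth), compound 1 gives only a limit, > 30000 nM. Compound 2 `COc1ccc(C(F)(F)F)cc1Nc1ncc(C(F)(F)F)c(N2Cc3cccc(N(C)S(C)(=O)=O)c3C2)n1` likewise gives only a limit in this assay, > 30000 nM. Compound 3 `CN(c1cccc2c1CN(c1nc(Nc3cc(Cl)cc(C(F)(F)F)c3)ncc1C(F)(F)F)C2)S(C)(=O)=O` gives 5500 nM in this assay. Compound 1 therefore stands at the weak end of the numbers shown, as does compound 2, because of the limit of > 30000 nM in this assay, at which 2 of the 3 values shown sit. Among the measured compounds shown here, the step of an at least 5.4-fold lower number from compound 1 to compound 3 (0.73 log units; beyond the scatter) is the one readable change, while a step that the two limits leave unreadable from compound 1 to compound 2 remains unreadable.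

Compound 4 `CN(c1cccc2c1CN(c1nc(Nc3ccc(Nc4ccccc4)cc3)ncc1C(F)(F)F)C2)S(C)(=O)=O` differs from compound 1 by anilino in place of trifluoromethyl on an aromatic carbon. For the measured compounds named here, no measured step alters this aromatic carbon; the two measured steps change the same aryl ring in other ways, and they show that such changes can either lower the number at least modestly, as in an at least 5.4-fold lower number from compound 1 to compound 3 (0.73 log units; beyond the scatter), or leave it at the limit, as in a step that the two limits leave unreadable from compound 1 to compound 2. With compound 1 at the limit, the expected step of an at least 2.0-fold lower number from compound 1 to compound 4 (0.30 log units; that floor lies within the scatter) is toward a lower number, of uncertain size. The estimate for compound 4 in this assay is 15000 nM, expected to fall between 3000 nM and 60000 nM, with a fair chance that only a limit is reported.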

Compound 4, concentration for 50% growth inhibition: 29800 nM
Compound 4: the middle estimate sits 2.0-fold (0.30 log units) below what was measured; low and high end bracket the measured number.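

Among the compounds shown here, with anilino on this aromatic carbon, para to a large group, compound 4 gives a measured number in this assay, 29800 nM, the first reading for a group other than trifluoromethyl at this place. Compound 1 gives > 30000 nM, which is a limit. The change brings in a six-membered aromatic ring and a hydrogen-bond donor, and the step is a number no higher from compound 1 to compound 4 (the limit leaves the size open); no size can be read from it because one end of the step is a limit: the limit of > 30000 nM in this assay, at which 2 of the 4 values shown sit.

The compounds shown leave open whether a smaller group on this aromatic carbon, such as a primary amine or a carboxylic acid, would give a step that can be read against a measured number rather than against a limit. They also leave open whether a substituent on the outer ring of the anilino group, such as a dimethylamino group, would move the number in this assay away from where compound 4 stands, 29800 nM.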